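From fluoro to chloro on the aromatic ring

This account rests on a few compounds, and the source may have more. Where it says the series, first, only, none or still open, it means among the compounds named here.

Values so far in a functional assay on SK-MEL-5 cells (Homo sapiens) for antiproliferative activity; a lower number here means a stronger inhibitor of growth, a higher number a weaker inhibitor of growth
compound 1 `Cc1ccnc2nc(-c3cccc(Cl)c3)cc(O)c12` gives 41.7 nM
compound 2 `Cc1cc(C)c2c(O)cc(-c3cccc(F)c3)nc2n1` gives 37.2 nM

Compound 2 stands within the scatter of compound 1, so these two values set no order. Compound 3 `Cc1cc(C)c2c(O)cc(-c3cccc(Cl)c3)nc2n1` differs from compound 2 by chloro in place of fluoro on an aromatic carbon and by nothing else. For the measured compounds named here, no measured pair shows this change alone. Compound 1 also carries chloro, and in this assay compound 1 gives 41.7 nM as its value. The expected change is none beyond the scatter, an estimated step of a 1.1-fold higher number from compound 2 to compound 3 (0.03 log units; within the scatter) in either direction. Compound 3 is expected at 40 nM, with an estimated range of 20 nM to 80 nM.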

Compound 3, concentration for 50% growth inhibition: 117 nM
For compound 3 the middle estimate is 2.9-fold (0.47 log units) below the measured one; measured number outside the range, above it.
By their numbers in this assay, from the lowest: compounds 2 and 1 (each within the scatter of the next); then compound 3.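

In this assay, chloro in place of fluoro on the six-membered aromatic ring of carbon only gives a 3.1-fold higher number from compound 2 to compound 3 (0.50 log units; beyond the scatter), so this position distinguishes the two halogens. With chloro held fixed, methyl in place of hydrogen on an aromatic carbon of the core gives a 2.8-fold higher number from compound 1 to compound 3 (0.45 log units; beyond the scatter), so that change also matters. Nothing available here explains either step. On these data alone, whether bromo, methoxy or an amine at the same place would give a lower or higher number remains open. So does whether the fluoro-to-chloro step holds without that added methyl.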